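Chloro substitution on the shared core of compound 2

A few compounds are considered here, and "the series" means these few. Any claim that something is new, unique, unknown or untested is made for them only; others in the source may bear on it.

Measured so far:
compound 1, `COc1ccc2[nH]c3c(c2c1)CCNC31CCN(C(C)c2ccccc2)CC1`, which in an assay on FRT cells for positive allosteric modulation of Cystic fibrosis transmembrane conductance regulator variant N1303K (Homo sapiens), in the presence of a further agent that is not named here (a lower number here means that less compound is needed, a higher number that more compound is needed for the effect), gives 20000 nM
compound 2, `Fc1ccc(CN2CCC3(CC2)NCCc2c3[nH]c3ccccc23)c(F)c1`, which in this assay gives 8200 nM

Compound 2 holds the lowest of the two numbers in this assay; the nearest is compound 1, whose number is higher by a margin beyond the usual scatter. Among the measured compounds shown here, the two compounds differ in more than one place, so their values show only that compound 2 needs less compound than compound 1 for the effect.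

Compound 3 `Fc1ccc(CN2CCC3(CC2)NCCc2c3[nH]c3ccc(Cl)cc23)c(F)c1` differs from compound 2 by chloro in place of hydrogen on an aromatic carbon. Neither measured compound carries a chloro group, so the effect of this change cannot be read from the pair. A modest step towards a lower number is expected, with the estimated step of a 1.6-fold lower number from compound 2 to compound 3 (0.21 log units; within the scatter) within or just beyond the scatter. Compound 3 is therefore estimated at 5000 nM, in a range from 1500 nM to 20000 nM.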

Compound 3, half-maximal effective concentration: 2500 nM
Compound 3: middle estimate off by 2.0-fold (0.30 log units), on the high side; the range from low to high includes it.
By their numbers in this assay, from the lowest: compound 3; then compound 2; then compound 1.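

In this assay, chloro in place of hydrogen on an aromatic carbon of the six-membered aromatic ring of carbon only, part of the fused system of four rings, gives a 3.3-fold lower number from compound 2 to compound 3 (0.52 log units; beyond the scatter) and so lies beyond the scatter. This single-place change shows what compound 1 and compound 2 could not: a substituent on this carbon is compatible with the effect, and the number responds to it, here moving lower. No measurement shown accounts for the size or direction of this step.

On these data alone, whether a bromo group, a nitrile or an amine on this same carbon would give a step of similar size remains open. As far as these compounds go, it is also open whether chloro on another carbon of this ring would lower the number as well.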